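This account rests on a few compounds, and the source may have more. Where it says the series, first, only, none or still open, it means among the compounds named here.

Compound 1 `O=C(NCCN1CCCC1)Nc1cc2c(Nc3ccc(F)c(Cl)c3)ncnc2cc1O[C@H]1CCOC1` serves as the reference of the set. In a functional assay on A-431 cells (Homo sapiens) for antiproliferative activity, read by sulforhodamine B assay, with a stated time of 72 h (a lower number here means a stronger inhibitor, a higher number a weaker inhibitor), compound 1 gives 247 nM, the lowest of the three numbers recorded so far. Compound 3 `O=C(Nc1cc2c(Nc3ccc(F)c(Cl)c3)ncnc2cc1O[C@H]1CCOC1)N1CCC(N2CCCC2)CC1` gives 317 nM, and a 1.3-fold higher number from compound 1 to compound 3 (0.11 log units; within the scatter), so the two stand together. Compound 2 `COC(CCNC(=O)Nc1cc2c(Nc3ccc(F)c(Cl)c3)ncnc2cc1O[C@H]1CCOC1)OC` gives 22000 nM; an 89-fold higher number from compound 1 to compound 2 (1.95 log units; beyond the scatter).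

Compound 4 `O=C(Nc1cc2c(Nc3ccc(F)c(Cl)c3)ncnc2cc1O[C@H]1CCOC1)N1CCC(CCO)CC1` has not yet been measured. Relative to compound 1 the change is 4-(2-hydroxyethyl)piperidin-1-yl in place of (2-(pyrrolidin-1-yl)ethyl)amino on a carbonyl carbon. Two recorded steps bear on it. The step of a 1.3-fold higher number from compound 1 to compound 3 (0.11 log units; within the scatter) shows that a piperidin-1-yl unit on the carbonyl carbon is well tolerated when it carries pyrrolidin-1-yl. The step of an 89-fold higher number from compound 1 to compound 2 (1.95 log units; beyond the scatter) shows that removal of pyrrolidin-1-yl from the chain is accompanied by a large rise. Among the compounds with values here, compound 4 carries no pyrrolidin-1-yl, so a higher number is expected, though no measured pair matches this exact exchange and the size remains uncertain. For compound 4 the expected step is a 12-fold higher number from compound 1 to compound 4 (1.08 log units; beyond the scatter). Compound 4 is estimated at 3000 nM, within 700 nM to 13000 nM.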

Compound 4, half-maximal inhibitory concentration: 759 nM
The estimate for compound 4 lay 4.0-fold (0.60 log units) above the measured number; measured number inside the range.
By their numbers in this assay, from the lowest: compounds 1 and 3 (each within the scatter of the next); then compound 4; then compound 2.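

In this assay the exchange at the carbonyl carbon gives a 3.1-fold higher number from compound 1 to compound 4 (0.49 log units; beyond the scatter) and so costs little, even though 4-(2-hydroxyethyl)piperidin-1-yl brings no pyrrolidin-1-yl. The ring-carbon exchange of pyrrolidin-1-yl for 2-hydroxyethyl gives a 2.4-fold higher number from compound 3 to compound 4 (0.38 log units; beyond the scatter) and stays modest, so within these compounds pyrrolidin-1-yl is not required for a number well short of that of compound 2. The exchange of the (3,3-dimethoxypropyl)amino group gives a 29-fold lower number from compound 2 to compound 4 (1.46 log units; beyond the scatter) and shows that the absence of pyrrolidin-1-yl alone does not account for compound 2; no measurement is available here that explains these differences.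

The compounds shown leave open whether the piperidine ring or the hydroxyl carries the gain over compound 2, which (2-hydroxyethyl)amino on the carbonyl carbon would separate. Also open, as far as these compounds go, is how a 3-hydroxypropyl chain, a dimethylamino group or a carboxylic acid would read on the same piperidine ring.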